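The compounds below may be only part of what the source reports. "The series", "measured", "known", "first", "only" and "open" are said of these compounds alone.

The compounds share one core. Compound 1 `Nc1nc(NC2CC2)c2ncn(/C=C3/CC3(CO)CO)c2n1` carries a cyclopropylamino group on it, compound 2 `Nc1nc(OCC(F)(F)F)c2ncn(/C=C3/CC3(CO)CO)c2n1` a 2,2,2-trifluoroethoxy group, and compound 3 `Nc1nc2c(ncn2/C=C2/CC2(CO)CO)c(=O)[nH]1` a carbonyl with an amide hydrogen instead. In an ADME assay on BCBL1 cells (Homo sapiens) for cytotoxicity, with a stated time of 7 days (a lower number here means that less compound is tolerated, a higher number that more compound is tolerated), compound 1 gives 71500 nM. In this assay compound 2 gives > 20000 nM, which is a limit of the assay and not a number. In this assay compound 3 gives > 20000 nM, likewise a limit. Compound 2 thus stands only at the limit of > 20000 nM in this assay, at which 2 of the 3 values shown sit. The step that the limit leaves unreadable from compound 1 to compound 2 cannot be sized for the same reason. Compound 4 `CC(C)Nc1nc(N)nc2c1ncn2/C=C1/CC1(CO)CO` differs from compound 2 in one place: isopropylamino in place of 2,2,2-trifluoroethoxy on an aromatic carbon. Among the measured compounds shown here, no measured step directly covers exchanging an ether for an amine; the only related change, a step that the limit leaves unreadable from compound 1 to compound 2, stays unreadable. Compound 4, like compound 1, carries a nitrogen-linked group rather than an ether, and compound 1 gives 71500 nM, so compound 4 is expected to be tolerated at a similarly high concentration, a step that the limit leaves unreadable from compound 2 to compound 4. That step may again escape reading in the same way as the step from compound 1 to compound 2. The estimate for compound 4 is 60000 nM, within a range from 20000 nM to 200000 nM.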

Compound 4, half-maximal cytotoxic concentration: > 20000 nM
Compound 4 was reported as a limit; the forecaster's own chance of this, stated with the estimate: 50%; the middle value does not contradict the limit.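

Compound 4 stands at a limit of the assay, so neither its step from compound 2 nor its step from compound 1 can be read: the limit of > 20000 nM in this assay, at which 3 of the 4 values shown sit.

The compounds shown leave open how much of compound 2 and compound 4 is tolerated in this assay and whether either differs from compound 1.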